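N-methylation of a cyclic imide in a mouse dose assay

The source may hold more compounds than are shown below. What is called first, only, known or untested is meant among the compounds shown, and "the series" means these compounds.

Compound 1 `O=C1CC[C@H](NC(=O)OCc2ccccc2)C(=O)N1` and compound 2 `CN1C(=O)CC[C@H](NC(=O)OCc2ccccc2)C1=O` share a six-membered core; compound 3 `O=C1C[C@H](NC(=O)OCc2ccccc2)C(=O)N1` has a five-membered core instead, and how the two cores differ is not broken down here. In a functional assay on the whole organism with Mus musculus as the target (a lower number here means that less compound is needed, a higher number that more compound is needed for the effect), compound 1 gives 43.1 mg/kg, compound 2 gives 36.1 mg/kg and compound 3 gives 103 mg/kg, the highest of the three. The change methyl in place of hydrogen on an amide-type nitrogen in a ring made a step of a 1.2-fold lower number from compound 1 to compound 2 (0.08 log units; within the scatter). Compound 4 `CN1C(=O)C[C@H](NC(=O)OCc2ccccc2)C1=O` carries the same kind of change, (methyl in place of hydrogen on an amide-type nitrogen in a ring), but on a five-membered non-aromatic ring with 1 nitrogen rather than a six-membered one. Because the step of a 1.2-fold lower number from compound 1 to compound 2 (0.08 log units; within the scatter) stayed within the scatter, a similarly small step is expected from compound 3 to compound 4, namely a 1.1-fold lower number from compound 3 to compound 4 (0.06 log units; within the scatter). Compound 4 is therefore estimated to give 90 mg/kg in this assay, between 45 mg/kg and 180 mg/kg.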

Compound 4, dose for half-maximal effect: 61.2 mg/kg
Compound 4: the middle estimate sits 1.5-fold (0.17 log units) above what was measured, and the stated range covers the measured number.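

In this assay, methyl in place of hydrogen on an amide-type nitrogen in a ring gave a 1.7-fold lower number from compound 3 to compound 4 (0.23 log units; within the scatter), so this step also stays small. Set beside the earlier step, the change behaves alike on the two cores: the same change on two cores in this assay, a 1.2-fold lower number (0.08 log units; within the scatter) from compound 1 to compound 2 and a 1.7-fold lower number (0.23 log units; within the scatter) from compound 3 to compound 4, 1.4-fold (0.15 log units) apart, within the scatter of two such steps. This shows that the change carried over from one core to the other in this assay, but as neither step stands out from the scatter, it does not show that methyl has a real effect on either core, and two pairs make no rule for other cores.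

The compounds shown leave open what a larger group on that nitrogen, such as ethyl or a longer chain, would do. They also leave open whether a carboxylic acid there would fit the same picture.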